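The compounds below may be only part of what the source reports. "The series", "measured", "known", "first", "only" and "open" are said of these compounds alone.

Compound 2 `CC(C)NC(=O)CC(c1ccc(-c2ccc3cccc(F)c3c2)[nH]c1=O)C(C)C` carries, on a saturated chain carbon bound to an aromatic carbon and a saturated chain carbon, an (isopropylcarbamoyl)methyl group, and in an assay on CHO cells for displacement of a labelled ligand from prostaglandin E2 receptor EP3 subtype (Homo sapiens), read by radioligand binding (on this read-out higher numbers stand for weaker inhibition and lower numbers for stronger inhibition), compound 2 gives 5.8 nM. For the measured compounds named here, its only measured neighbour is compound 1 `CC(C)C(c1ncc[nH]1)c1ccc(-c2ccc3cccc(F)c3c2)[nH]c1=O`, which in this assay gives 7.3 nM; the two values lie within the scatter of each other, so neither can be set above the other. Going by the values given here, the one step that bears on the position in question is the exchange of 1H-imidazol-2-yl for (isopropylcarbamoyl)methyl, which gave a 1.3-fold lower number from compound 1 to compound 2 (0.10 log units; within the scatter). Compound 3 `CC(C)C(c1noc(=O)[nH]1)c1ccc(-c2ccc3cccc(F)c3c2)[nH]c1=O` differs from compound 2 in one place: a group of 6 heavy atoms (2 carbon, 2 nitrogen, 2 oxygen; one five-membered aromatic ring with 3 hetero atoms) in place of a group of 7 heavy atoms (5 carbon, 1 nitrogen, 1 oxygen; no ring), on a saturated chain carbon bound to an aromatic carbon and a saturated chain carbon. Among the compounds with values here, the single relevant step shows that a ring with a hydrogen-bond donor and an open chain with an amide read alike here, which makes a large move unlikely, though one step is thin ground. Compound 3 is therefore expected to give about 6 nM, within a range of 2 nM to 20 nM, corresponding to an expected step of a 1.0-fold higher number from compound 2 to compound 3 (0.01 log units; within the scatter).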

Compound 3, inhibition constant: 15 nM
The estimate for compound 3 lay 2.5-fold (0.40 log units) below the measured number; the range from low to high includes it.
By their numbers in this assay, from the lowest: compounds 2 and 1 (each within the scatter of the next); then compound 3.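

At the saturated chain carbon bound to an aromatic carbon and a saturated chain carbon, the earlier pair in this assay had not separated, but the one-ring group of compound 3 now gives a step beyond the scatter: a 2.6-fold higher number from compound 2 to compound 3 (0.41 log units; beyond the scatter), and likewise a 2.1-fold higher number from compound 1 to compound 3 (0.31 log units; beyond the scatter). The position therefore does not read every group alike, and exchanging one five-membered aromatic ring for another is enough to register a modest change, even though the 1H-imidazol-2-yl ring and the open-chain (isopropylcarbamoyl)methyl group could not be told apart. Compound 3 stands apart from both neighbours by a similar modest margin, but no measurement here accounts for this difference.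

The three compounds leave open how far the number would move at this place with a carboxylic acid, an amine or a longer chain ending in the same amide. They also leave open whether the ring oxygen or the ring carbonyl of compound 3 accounts for its separation, which a 1,2,4-oxadiazole without the carbonyl or a 1,2,4-triazole could begin to test.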